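The source may report more compounds than this note shows. Statements on the series, on what has been measured and on what is new or still open speak of the compounds shown alone.

Measured so far in a functional assay on the whole organism for antagonist activity, with Mus musculus as the target; a lower number here means that less compound is needed, a higher number that more compound is needed for the effect:
Compound 1, `COc1ccc(CN2CCC(C(=O)Nc3cc(Cl)c(N)cc3OC)CC2)cc1`: 0.9 mg/kg
Compound 2, `CCCCCN1CCC(C(=O)Nc2cc(Cl)c(N)cc2OC)CC1`: > 10 mg/kg (a limit of the assay, not a number)

Compound 2 stands at the edge of what this assay can report: the value given for compound 2 is only a limit, (the limit of > 10 mg/kg in this assay, at which 1 of the 2 values shown sits), so how much compound 2 really needs is not known beyond that. Compound 3, `COc1cccc(CN2CCC(C(=O)Nc3cc(Cl)c(N)cc3OC)CC2)c1`, differs from compound 2 in one place: 3-methoxyphenyl in place of butyl on a saturated chain carbon bound to an amine nitrogen in a ring. Among the measured compounds shown here, the one measured step that bears on this runs in the opposite direction, an at least 11-fold higher number from compound 1 to compound 2 (1.04 log units; beyond the scatter), where a methoxyphenyl group at that same position was exchanged for butyl and the dose rose out of the measurable range. Compound 3 puts a methoxyphenyl group back, as 3-methoxyphenyl rather than the 4-methoxyphenyl of compound 1, so a large step downward in this assay is expected, of roughly the size seen before. The expected step is an at least 5.0-fold lower number from compound 2 to compound 3 (0.69 log units; beyond the scatter). Compound 3 is therefore estimated at 2 mg/kg, with a range from 0.5 mg/kg to 8 mg/kg, kept wide since the limit on compound 2 leaves the starting point open and the methoxyphenyl is not the same isomer as in compound 1.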

Compound 3, dose for half-maximal effect: > 4 mg/kg
Compound 3: a limit, no number; the forecaster's own chance of this, stated with the estimate: 20%; middle value at least 2.0-fold (0.30 log units) from the limit.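

In this assay, among the compounds shown here, 3-methoxyphenyl in place of 4-methoxyphenyl gives an at least 4.4-fold higher number from compound 1 to compound 3 (0.64 log units; beyond the scatter), so at this position it matters where the methoxy group sits on the aromatic ring, and not only that a ring is present. The earlier step exchanged the whole methoxyphenyl group for butyl, which left open whether any methoxyphenyl group would serve; compound 3 shows that this one does not match compound 1, even though the two differ only in the place of the methoxy group. Compound 3 is given only as a limit, > 4 mg/kg, and compound 2 is also given only as a limit, so the step joining them cannot be read and butyl and 3-methoxyphenyl cannot be ranked against each other.

From the compounds shown here alone, how far compound 3 really lies from compound 1 remains unknown, since the limit gives no true dose for it. A plain phenyl group without methoxy, or a 2-methoxyphenyl group, at this same position would help show whether the 4-methoxyphenyl of compound 1 is a special case or whether the methoxy group in compound 3 is what costs the effect.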